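The compounds below may be only part of what the source reports. "The series", "measured", "known", "first", "only" and "open" are said of these compounds alone.

Compound 1 `O=C1/C(=C/c2ccccc2)CCC/C1=C\c1ccc([N+](=O)[O-])cc1`: 20000 nM
Compound 2 `Cc1ccc(/C=C2\CCC/C(=C\c3ccc([N+](=O)[O-])cc3)C2=O)cc1`: 27000 nM

In a functional assay on HL-60 cells (Homo sapiens) for cytotoxicity, with a stated time of 24 h (on this read-out lower numbers stand for higher toxicity in this test and higher numbers for lower toxicity in this test), compound 2 gives 27000 nM, a number within the scatter of compound 1. Compound 3 `COc1ccc(/C=C2\CCC/C(=C\c3ccc([N+](=O)[O-])cc3)C2=O)cc1` has methoxy in place of methyl on an aromatic carbon, para to a large group: methoxy in place of methyl on an aromatic carbon. Within the data shown here, only one measured step bears on this change, a swap of hydrogen for methyl on an aromatic carbon: a 1.4-fold higher number from compound 1 to compound 2 (0.13 log units; within the scatter). That single small step gives no reason to expect a change beyond the scatter in this assay. The expected change is a 1.2-fold lower number from compound 2 to compound 3 (0.07 log units; within the scatter). For compound 3, the estimate is 23000 nM, with an expected range from 11000 nM to 46000 nM.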

Compound 3, half-maximal cytotoxic concentration: > 400000 nM
Compound 3 gave a limit, no number (the forecaster's own chance of this, stated with the estimate: 5%); middle value at least 17-fold (1.24 log units) away from the limit.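

In this assay, the aromatic carbon para to a large group proves sensitive to what it carries: methoxy in place of methyl gives an at least 14-fold higher number from compound 2 to compound 3 (1.17 log units; beyond the scatter), and methoxy in place of hydrogen gives an at least 20-fold higher number from compound 1 to compound 3 (1.30 log units; beyond the scatter). Methyl in place of hydrogen had stayed within the scatter, so the earlier step gave no sign of this. Compound 3 gives a limit, not a number: the limit of > 400000 nM in this assay, at which 1 of the 3 values shown sits.

The compounds shown leave open whether the oxygen of methoxy or simply the longer group goes with this shift. From the compounds shown here alone, how a hydroxyl, an ethyl or an amine on this carbon would read remains unknown.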